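Lengthening the Acid Chain on a Receptor Assay

This account rests on a few compounds, and the source may have more. Where it says the series, first, only, none or still open, it means among the compounds named here.

Compound 1 `Cc1cc(C(=O)O)ccc1-c1noc(-c2ccc(C3CCCCC3)cc2)n1` was tested in a functional assay on CHO cells with sphingosine 1-phosphate receptor 4 (Homo sapiens) as the target, read by GTPgammaS binding; on this read-out higher numbers stand for an effect only at larger amounts of compound and lower numbers for an effect already at smaller amounts. In this assay compound 1 gives > 10000 nM, which is a limit of the assay and not a number. Two related compounds share the same outcome. Compound 2 `Cc1cc(CCC(=O)O)ccc1-c1noc(-c2ccc(OC(C)C)c(Br)c2)n1` gives > 10000 nM in this assay, again a limit. Compound 3 `CC[C@H](C)Oc1ccc(-c2nc(-c3ccc(CCC(=O)O)cc3C)no2)cc1C#N` gives > 10000 nM in this assay, also a limit. All three shown values thus sit at the same ceiling, (the limit of > 10000 nM in this assay, at which 3 of the 3 values shown sit), and no step between measured compounds can be drawn from them.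

Compound 4 `Cc1cc(CCCC(=O)O)ccc1-c1noc(-c2ccc(C3CCCCC3)cc2)n1` differs from compound 1 in one place: 3-carboxypropyl in place of carboxy on an aromatic carbon. For the measured compounds named here, with no measured step to lean on, nothing in these numbers points in either direction for this assay. The expected change in this assay is an at least 1.2-fold lower number from compound 1 to compound 4 (0.09 log units; that floor lies within the scatter), a guess rather than a reading. Compound 4 is therefore estimated at 8000 nM, with a range from 1000 nM to 30000 nM, and it may well come back as a limit once more.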

Compound 4, half-maximal effective concentration: > 10000 nM
Compound 4: only a limit was reported; the forecaster's own chance of this, stated with the estimate: 60%; at least 1.2-fold (0.09 log units) between middle value and limit.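

No step can be read between compound 1 and compound 4, as both stop at a limit in this assay: the limit of > 10000 nM in this assay, at which 4 of the 4 values shown sit.

The compounds shown leave open whether any structural change here would bring a readable number in this assay.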